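A Phenyl Replaces a Methyl on the Less Stable Compound

The source may report more compounds than this note shows. Statements on the series, on what has been measured and on what is new or still open speak of the compounds shown alone.

Among the compounds with values here, in an ADME assay on microsomes from liver (Homo sapiens) for metabolic stability, with a stated time of 10 min, tested at 0.5 uM (on this read-out lower numbers stand for a less stable compound and higher numbers for a more stable compound), compound 1 `Cc1noc(C)c1[C@@H]1C[C@@](C)(c2ccc(F)cc2F)N=C(N)S1` gives 24%, the lower of the two numbers so far, while compound 2 `Cc1noc(C)c1[C@@H]1C[C@@](C)(c2ccc(F)cc2)N=C(N)S1` gives 73%. Compound 3 `Cc1onc(-c2ccccc2)c1[C@@H]1C[C@@](C)(c2ccc(F)cc2F)N=C(N)S1` keeps the core of compound 1 and alters one group: phenyl in place of methyl on an aromatic carbon. Within the data shown here, the only measured step, a number 49 percentage points higher from compound 1 to compound 2 (beyond the scatter), is large, but it comes from hydrogen in place of fluoro on an aromatic carbon, a different change. It shows that one edit can move this read-out far, yet it gives no direction for the new group. With compound 1 at 24%, little room remains beneath it, so only a slight fall, within the scatter, is expected. The estimated shift is a number 7 percentage points lower from compound 1 to compound 3 (within the scatter). In this assay, compound 3 is expected to give 17%, with an estimated range from 4% to 40%.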

Compound 3, percent of the compound remaining: 38%
Compound 3: middle estimate off by 21 percentage points, on the low side; low and high end bracket the measured number.
By their numbers in this assay, from the lowest: compound 1; then compound 3; then compound 2.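

Replacing methyl with phenyl at this position, on an aromatic carbon next to the ring nitrogen, gives a number 14 percentage points higher from compound 1 to compound 3 (beyond the scatter) in this assay. Within the data shown here, the earlier step changed a fluoro elsewhere in the molecule, so this is the first sign that the group on the five-membered aromatic ring can also move this read-out, and that a much larger all-carbon ring can sit here with no loss of stability. Nothing measured here gives a reason for the rise.

Going by these compounds, what an amine, a carboxylic acid or a longer chain would do at the same position remains open, as a single swap cannot show a trend. Also open, on these data alone, is whether phenyl would raise the number on compound 2, which already stands at 73%.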